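This account rests on a few compounds, and the source may have more. Where it says the series, first, only, none or still open, it means among the compounds named here.

Measured so far in a functional assay on the whole organism (strain Swiss) with Mus musculus as the target, in the maximal electroshock model, with a stated time of 2 h, at a dose of 300 mg/kg by the intraperitoneal route; on this read-out higher numbers stand for a stronger effect at the one dose given and lower numbers for a weaker effect:
- compound 1, `CCC(C(=O)N1CCN(c2cccc(Cl)c2)CC1)N1C(=O)CCC1=O`: 25%
- compound 2, `COc1cccc(N2CCN(C(=O)C(C)N3C(=O)CCC3=O)CC2)c1`: 0%
- compound 3, `CCC(C(=O)N1CCN(c2ccc(C(F)(F)F)cc2)CC1)N1C(=O)CCC1=O`: 0%

Of the compounds shown here, three sharing one core have been tested. Compound 2 gives 0% in this assay, and compound 3 gives 0%, the same number at the digits recorded, so these two stand together at the bottom of the set and no order can be drawn between them. Compound 1, at 25%, sits clearly above both, a gap beyond the usual scatter of repeated measurements.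

Compound 4, `CC(C(=O)N1CCN(c2cccc(Cl)c2)CC1)N1C(=O)CCC1=O`, has not yet been measured. It differs from compound 2 in a single place: chloro in place of methoxy on an aromatic carbon. Cut one bond further out, the same difference reads 3-methoxyphenyl to 3-chlorophenyl. Within the data shown here, no measured pair shows this exact change, so the size of its effect is unknown. Compound 2 stands at the bottom of the set with 0%, and compound 1 shows that 25% is reachable within this core. A modest upward step from compound 2 to compound 4 is therefore expected, a number 10 percentage points higher from compound 2 to compound 4 (within the scatter), possibly no larger than the scatter. Compound 4 is estimated at 10%, with a range from 0% to 30%.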

Compound 4, a percentage reported as activity, at one dose (the size of the read-out at that dose, not a potency): 50%
Beside the measured number, compound 4's estimate is 40 percentage points below it, and the stated range ends below it.
By their numbers in this assay, from the lowest: compounds 2 and 3 (each within the scatter of the next); then compound 1; then compound 4.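

In this assay, chloro in place of methoxy on an aromatic carbon, meta to a large group, brings a number 50 percentage points higher from compound 2 to compound 4 (beyond the scatter), so this single ring position can carry a large change in the read-out within the shared core. The side chain matters as well: hydrogen in place of methyl on a saturated chain carbon, with the 3-chlorophenyl kept, brings a number 25 percentage points higher from compound 1 to compound 4 (beyond the scatter). Nothing at hand explains why either change acts as it does.

Still open, on these data alone, is whether chloro is special at this ring position, or whether a fluoro, a bromo, a methyl or a nitrile on the same aromatic carbon would do as well. As far as these compounds go, it is also open whether a propyl chain or a bare methylene at the chain carbon would continue the trend seen with these two compounds.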